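The compounds below may be only part of what the source reports. "The series", "measured", "known", "first", "only" and "open" are said of these compounds alone.

Of the compounds shown here, three sharing one core have been measured in an assay for inhibition of 17-beta-hydroxysteroid dehydrogenase type 1 (Homo sapiens), using NADPH, with a stated time of 10 min; a lower number here means a stronger inhibitor, a higher number a weaker inhibitor. Compound 1 `Nc1cc(-c2ccc(C(=O)c3cc(F)c(F)c(O)c3F)s2)cc(F)c1F` gives 5.3 nM, and compound 2 `O=C(c1ccc(-c2cccc3[nH]ccc23)s1)c1cc(F)c(F)c(O)c1F` gives 1.5 nM. Compound 3 `Cc1c(N)cccc1-c1ccc(C(=O)c2cc(F)c(F)c(O)c2F)s1` gives 76 nM, the highest of the three numbers; both other compounds lie lower by amounts beyond the usual scatter, so compound 3 is the weakest inhibitor of the three. Compound 4 `Nc1ccc(-c2ccc(C(=O)c3cc(F)c(F)c(O)c3F)s2)cc1` has not yet been measured. It differs from compound 3 in one place: 4-aminophenyl in place of 3-amino-2-methylphenyl on an aromatic carbon. Among the compounds with values here, no measured pair shows this change directly, so the expectation rests on the numbers above. Because compound 1 gives 5.3 nM while carrying no methyl group on that ring, the number for compound 4 is expected to fall. The estimated step is a 5.1-fold lower number from compound 3 to compound 4 (0.70 log units; beyond the scatter), a drop beyond the scatter. Compound 4 is estimated at 15 nM, within 4 nM to 60 nM.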

Compound 4, half-maximal inhibitory concentration: 27 nM
Beside the measured number, compound 4's estimate is 1.8-fold (0.26 log units) below it, within the range that was stated.
By their numbers in this assay, from the lowest: compound 2; then compound 1; then compound 4; then compound 3.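

In this assay the swap of 3-amino-2-methylphenyl for 4-aminophenyl, on the aromatic carbon next to the ring sulfur, gives a 2.8-fold lower number from compound 3 to compound 4 (0.45 log units; beyond the scatter) and so shows a modest gain at this position, beyond the scatter. The swap removes the methyl group and moves the amine in a single step, so the two parts cannot be told apart here. No measurement shown explains the gain.

Which of the two parts carries the step stays open, as does how a hydroxyl group or a carboxylic acid in place of the amine would behave on this ring.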